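Removing the Methyl from an Amino Group

The source may hold more compounds than are shown below. What is called first, only, known or untested is meant among the compounds shown, and "the series" means these compounds.

Measured compounds:
compound 1 `O=C1C(Cl)=C(Cl)C(=O)c2ncccc21`: 31800 nM
compound 2 `CNC1=C(Cl)C(=O)c2ncccc2C1=O`: 2450 nM
compound 3 `CNC1=C(SC)C(=O)c2ncccc2C1=O`: 3440 nM

In a functional assay on HL-60 cells (Homo sapiens) for antiproliferative activity, read by MTT assay, with a stated time of 48 h (a lower number here means a stronger inhibitor, a higher number a weaker inhibitor), compound 2 gives the lowest of the three numbers; compound 3 sits within the usual scatter of it, while compound 1 lies well beyond it. Compound 4 `NC1=C(Cl)C(=O)c2ncccc2C1=O` differs from compound 2 by hydrogen in place of methyl on an amine nitrogen. Neither measured step touches this nitrogen: a 13-fold lower number from compound 1 to compound 2 (1.11 log units; beyond the scatter) was large and a 1.4-fold higher number from compound 2 to compound 3 (0.15 log units; within the scatter) stayed within the scatter, but both exchanged groups on a double-bonded ring carbon. The data give no guide to what the loss of the methyl does, so for compound 4 the expected step of a 1.0-fold higher number from compound 2 to compound 4 (0.01 log units; within the scatter) is one of no clear size beyond the scatter. Compound 4 is therefore estimated at 2500 nM, in a range from 800 nM to 8000 nM.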

Compound 4, half-maximal inhibitory concentration: 3260 nM
Compound 4: the middle estimate sits 1.3-fold (0.12 log units) below what was measured, and the stated range covers the measured number.
By their numbers in this assay, from the lowest: compounds 2, 4 and 3 (each within the scatter of the next); then compound 1.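

Removing the methyl from this amine nitrogen gives a 1.3-fold higher number from compound 2 to compound 4 (0.12 log units; within the scatter) and so leaves the number within the scatter, which means that amino and methylamino cannot be told apart in this pair. Placing amino instead of chloro on the double-bonded ring carbon gives a 9.8-fold lower number from compound 1 to compound 4 (0.99 log units; beyond the scatter) even without the methyl, so the methyl is not needed for compound 4 to stay well clear of compound 1. No measurement shown here explains either step.

Only hydrogen and methyl appear on this nitrogen. As far as these compounds go, how an ethyl group, a longer chain or a benzyl group would behave there remains open.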